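The source may report more compounds than this note shows. Statements on the series, on what has been measured and on what is new or still open speak of the compounds shown alone.

Compound 1 `CC1=NN(c2ccccc2)C(=O)[C@]12C(=O)C=CC[C@H]2c1ccc(C)cc1`: 4220 nM
Compound 2 `COc1ccccc1[C@@H]1CC=CC(=O)[C@]12C(=O)N(c1ccccc1)N=C2C`: 2850 nM
Compound 3 `CC1=NN(c2ccccc2)C(=O)[C@]12C(=O)C=CC[C@H]2c1ccccc1`: not yet measured

All values come from a functional assay on HCT-116 cells (Homo sapiens) for inhibition, read by MTT assay, with a stated time of 72 h; on this read-out higher numbers stand for weaker inhibition and lower numbers for stronger inhibition. Compound 2 at 2850 nM lies within the scatter of compound 1 at 4220 nM, so the two cannot be ranked. Compound 3 is the next point of interest, and its difference from compound 2 is hydrogen in place of methoxy on an aromatic carbon. This places hydrogen in place of methoxy on an aromatic carbon, ortho to a large group, so that 2-methoxyphenyl becomes phenyl. Within the data shown here, only one measured step bears on this change: a 1.5-fold lower number from compound 1 to compound 2 (0.17 log units; within the scatter). That step put 2-methoxyphenyl in place of 4-methylphenyl on a saturated ring carbon, and it remained within the scatter. Among the measured compounds shown here, no measured pair shows the removal of methoxy alone, so this step is only a loose guide. On that limited evidence, no change beyond the scatter is expected in this assay. The expected step is a 1.2-fold higher number from compound 2 to compound 3 (0.09 log units; within the scatter). For compound 3 the estimated value is 3500 nM, with an expected range of 1500 nM to 8000 nM.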

Compound 3, half-maximal inhibitory concentration: 5300 nM
The estimate for compound 3 lay 1.5-fold (0.18 log units) below the measured number; the range from low to high includes it.
By their numbers in this assay, from the lowest: compounds 2, 1 and 3 (each within the scatter of the next).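

In this assay the removal of methoxy alone can now be read directly: 2-methoxyphenyl to phenyl gives a 1.9-fold higher number from compound 2 to compound 3 (0.27 log units; within the scatter) and supplies the single-change comparison that the earlier pair lacked. Hydrogen in place of methyl on an aromatic carbon gives a 1.3-fold higher number from compound 1 to compound 3 (0.10 log units; within the scatter) and completes a set of three aryl variants on the shared core, none of which can be ranked against the others on these steps, so neither methoxy nor methyl has yet produced a readable difference from the plain phenyl compound 3. No measurement at hand accounts for these numbers lying so close together.

The compounds shown leave open whether any substituent on this aromatic ring can move the number beyond the scatter, for example an amine, a carboxylic acid, a chlorine atom or a longer alkyl chain. Among these compounds, they also leave open how the number responds to changes elsewhere on the shared core, since every step so far concerns this one aromatic ring.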